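Fluorine on the Benzyl Ring of Two Purine-Type Cores

The compounds below may be only part of what the source reports. "The series", "measured", "known", "first", "only" and "open" are said of these compounds alone.

Compound 1 `c1ccc(C[n+]2c[nH]c3ncncc32)cc1` and compound 2 `Fc1ccc(C[n+]2c[nH]c3ncncc32)cc1` share one core, and compound 3 `Fc1ccc(Cn2cnc3c(Sc4ccccc4)ncnc32)cc1` carries a second core; the difference between the two cores is not broken down here. In an assay on isolated protein for inhibition of Rho-associated protein kinase 1 (Homo sapiens), tested at 30 uM (a higher number here means more inhibition at the concentration tested (going by the name of the read-out), a lower number less inhibition), compound 1 gives 7%, compound 2 gives 4% and compound 3 gives 2%. The change fluoro in place of hydrogen on an aromatic carbon produced a number 3 percentage points lower from compound 1 to compound 2 (within the scatter). Compound 4 `Fc1ccc(Cn2cnc3c(Sc4ccc(F)cc4)ncnc32)cc1` is not yet measured; it arises from compound 3 by fluoro in place of hydrogen on an aromatic carbon, the same change at the same kind of place. For compound 4 the expected step is a number 1 percentage points higher from compound 3 to compound 4 (within the scatter), because a number 3 percentage points lower from compound 1 to compound 2 (within the scatter) was within the scatter and compound 3 starts from 2% in this assay. Compound 4 is therefore estimated at 3%, between 0% and 12%.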

Compound 4, a percentage reported as inhibition, at one concentration (the size of the read-out at that concentration, not a potency): 0%
Estimate against measurement, compound 4: 3 percentage points above; low and high end bracket the measured number.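

In this assay, fluoro in place of hydrogen on the phenyl ring of the phenylsulfanyl group gives a number 2 percentage points lower from compound 3 to compound 4 (within the scatter). The step agrees with the earlier one: the same change on two cores in this assay, a number 3 percentage points lower (within the scatter) from compound 1 to compound 2 and a number 2 percentage points lower (within the scatter) from compound 3 to compound 4, 1 percentage points apart, within the scatter of two such steps. Within these compounds the change therefore carries from one core to the other as a step lost in the scatter, but it does not show that the two cores would respond alike in a compound with clear inhibition, since all four numbers are small and each comes from a single concentration.

As far as these compounds go, it remains open whether a different group at the same place on the ring, such as an amine or a carboxylic acid, would give a step beyond the scatter. Also open, from the compounds shown here alone, is what a longer chain in place of the phenylsulfanyl group would do.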